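The source may hold more compounds than are shown below. What is called first, only, known or untested is meant among the compounds shown, and "the series" means these compounds.

In a functional assay on MCF7 cells (Homo sapiens) for inhibition, read by MTT assay, with a stated time of 24 h (on this read-out higher numbers stand for weaker inhibition of growth and lower numbers for stronger inhibition of growth), the values so far are:
compound 1 `COc1ccc2c(c1)c(-c1nc3ccccc3n1C(=O)c1ccccc1)cn2C` gives 38400 nM
compound 2 `COc1cccc(C(=O)n2c(-c3cn(C)c4ccc(OC)cc34)nc3ccccc32)c1` gives 14600 nM
compound 3 `Cn1cc(-c2nc3ccccc3n2C(=O)c2ccccc2)c2cc(Br)ccc21` gives 50300 nM

Compound 3 stands level with compound 1, the step between them being a 1.3-fold higher number from compound 1 to compound 3 (0.12 log units; within the scatter) and so no real separation. Both carry higher numbers than compound 2 at 14600 nM on this read-out.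

Compound 4 `COc1cccc(C(=O)n2c(-c3cn(C)c4ccc(Br)cc34)nc3ccccc32)c1` differs from compound 3 by methoxy in place of hydrogen on an aromatic carbon in one place, methoxy in place of hydrogen on an aromatic carbon, which reads as benzoyl to (3-methoxyphenyl)carbonyl.

The same change has been measured once, as a 2.6-fold lower number from compound 1 to compound 2 (0.42 log units; beyond the scatter) on the core of compound 1, a modest step beyond the scatter. The swap of bromo in place of methoxy between compound 1 and compound 3 did not separate their values, so that step is taken to carry over to the bromo compound. Going by the values given here, this rests on a single pair, and no measurement yet tests it with bromo present.

A step of similar size toward a lower number is expected, namely a 2.5-fold lower number from compound 3 to compound 4 (0.40 log units; beyond the scatter) as the estimated move. The estimated value for compound 4 is 20000 nM with a range of 9000 nM to 45000 nM as expected bounds.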

Compound 4, concentration for 50% growth inhibition: 18200 nM
Estimate against measurement, compound 4: 1.1-fold (0.04 log units) above, within the range that was stated.
By their numbers in this assay, from the lowest: compounds 2 and 4 (each within the scatter of the next); then compounds 1 and 3 (each within the scatter of the next).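

In this assay, the change from benzoyl to (3-methoxyphenyl)carbonyl now has a second reading with bromo on the core, a 2.8-fold lower number from compound 3 to compound 4 (0.44 log units; beyond the scatter), so the step no longer rests on the core of compound 1 alone and holds on both cores shown: the same change on two cores in this assay, a 2.6-fold lower number (0.42 log units; beyond the scatter) from compound 1 to compound 2 and a 2.8-fold lower number (0.44 log units; beyond the scatter) from compound 3 to compound 4, 1.1-fold (0.02 log units) apart, within the scatter of two such steps. The swap of bromo in place of methoxy, which left compound 1 and compound 3 unseparated, also stays within the scatter with the 3-methoxyphenyl group present, a 1.2-fold higher number from compound 2 to compound 4 (0.10 log units; within the scatter): the same change on two cores in this assay, a 1.3-fold higher number (0.12 log units; within the scatter) from compound 1 to compound 3 and a 1.2-fold higher number (0.10 log units; within the scatter) from compound 2 to compound 4, 1.1-fold (0.02 log units) apart, within the scatter of two such steps. Across these four compounds the two changes therefore read as independent of each other, with the number following the group on the benzoyl ring and not the bromo or methoxy on the core, and no compound goes against this.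

From the compounds shown here alone, the reading covers only hydrogen and methoxy at this one place on the ring, so whether a hydroxy, an amine, a carboxylic acid or a longer chain such as butoxy would move the number in the same way stays open. Going by these compounds, whether the step carries over to other cell lines or other exposure times also stays open.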